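A few compounds are considered here, and "the series" means these few. Any claim that something is new, unique, unknown or untested is made for them only; others in the source may bear on it.

Compound 3, `CC(C)c1nnc(-c2ccc(N3CCC(Oc4ccccc4C(F)(F)F)CC3)nn2)s1`, belongs to a set of three compounds that share one core and differ only in the group carried on one aromatic carbon at the far end of that core. In an assay on microsomes from liver for inhibition of acyl-CoA desaturase 1 (Rattus norvegicus) (on this read-out higher numbers stand for weaker inhibition and lower numbers for stronger inhibition), compound 3 gives 8.8 nM, the second highest of the three numbers. Compound 1, `O=C(NCCC1CC1)c1ccc(N2CCC(Oc3ccccc3C(F)(F)F)CC2)nn1`, gives 14 nM in this assay, and compound 2, `FC(F)(F)c1ccccc1OC1CCN(c2ccc(-n3ccnc3)nn2)CC1`, gives 4 nM. The steps among these three are all of small to modest size: a 3.5-fold lower number from compound 1 to compound 2 (0.54 log units; beyond the scatter), a 1.6-fold lower number from compound 1 to compound 3 (0.20 log units; within the scatter), and a 2.2-fold higher number from compound 2 to compound 3 (0.34 log units; beyond the scatter). Compound 4, `Oc1nnc(-c2ccc(N3CCC(Oc4ccccc4C(F)(F)F)CC3)nn2)s1`, carries the change (hydroxy in place of isopropyl on an aromatic carbon), that is, hydroxy in place of isopropyl on an aromatic carbon of the five-membered aromatic ring of compound 3. Among the measured compounds shown here, no measured pair exchanges a group on that ring itself; the three measured steps show only that exchanging the whole group on the aromatic carbon of the core shifts this assay by modest amounts at most. A step of no more than modest size is therefore expected, a 2.3-fold higher number from compound 3 to compound 4 (0.36 log units; beyond the scatter), with the direction left open by the data. Compound 4 is estimated to give 20 nM in this assay, within a range from 6 nM to 70 nM.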

Compound 4, half-maximal inhibitory concentration: 6.1 nM
Compound 4: the middle estimate sits 3.3-fold (0.52 log units) above what was measured, and the stated range covers the measured number.
By their numbers in this assay, from the lowest: compounds 2, 4, 3 and 1 (each within the scatter of the next, the first and the last beyond it).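

The first change made on the five-membered ring itself, hydroxy in place of isopropyl on the aromatic carbon next to the ring nitrogen and next to the ring sulfur, gives a 1.4-fold lower number from compound 3 to compound 4 (0.16 log units; within the scatter) in this assay, so this exchange of a carbon-only group for one with a hydrogen-bond donor and acceptor leaves the two compounds unresolved. Set against the other groups on the shared core, the 5-hydroxy-1,3,4-thiadiazol-2-yl group gives a 1.5-fold higher number from compound 2 to compound 4 (0.18 log units; within the scatter), which places it within the scatter of the 1H-imidazol-1-yl compound, and a 2.3-fold lower number from compound 1 to compound 4 (0.36 log units; beyond the scatter), which separates it from the (2-cyclopropylethyl)carbamoyl compound. That separation should not be read as an advantage of hydroxy over isopropyl, since compound 3 and compound 4 themselves stay within the scatter of each other.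

Only isopropyl and hydroxy are shown on this carbon, so it stays open whether an amine, a carboxylic acid or a longer alkyl chain there would also leave the number in this narrow range. Nothing at hand bears on why the isopropyl and hydroxy compounds read so alike.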